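Swapping a benzoyl-type arm for a methoxybenzyl arm

The source may report more compounds than this note shows. Statements on the series, on what has been measured and on what is new or still open speak of the compounds shown alone.

Among the measured compounds shown here, compound 3 `CCN1CCN(CCCn2cnc3c(N4CCN(C5CCCC5)CC4)nc(NC(=O)c4ccc(CN(C)C)cc4)nc32)CC1` gives the lowest number of the two numbers measured so far in an assay on HEK293 cells for antagonist activity at Toll-like receptor 9 (Homo sapiens), read by spectrophotometry (on this read-out higher numbers stand for weaker inhibition and lower numbers for stronger inhibition), at 60 nM. Its nearest neighbour is compound 1 `CCN1CCN(CCCn2cnc3c(N4CCN(C5CCCC5)CC4)nc(NCc4ccc(F)cc4)nc32)CC1`, which gives 250 nM in this assay. Compound 2 `CCN1CCN(CCCn2cnc3c(N4CCN(C(=O)C5CCCC5)CC4)nc(NCc4ccc(OC)cc4)nc32)CC1` reaches only the limit of this assay, > 30000 nM, a limit and not a number (the limit of > 30000 nM in this assay, at which 1 of the 3 values shown sits). Compound 4 `CCN1CCN(CCCn2cnc3c(N4CCN(C5CCCC5)CC4)nc(NCc4ccc(OC)cc4)nc32)CC1` has not yet been measured; it differs from compound 3 in one place, (4-methoxybenzyl in place of (4-((dimethylamino)methyl)phenyl)carbonyl on a nitrogen on an aromatic ring).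

For the measured compounds named here, only one measured step bears on this change. Going a 4.2-fold lower number from compound 1 to compound 3 (0.62 log units; beyond the scatter) was the move in the other direction, a carbonyl-linked arm taking the place of a benzyl-type arm, and it brought a modest gain beyond the scatter. Undoing that kind of change in compound 4 is therefore expected to cost roughly the same amount, so a step of a 4.2-fold higher number from compound 3 to compound 4 (0.62 log units; beyond the scatter) is estimated, leaving compound 4 near compound 1. Compound 4 is expected to give about 250 nM in this assay, with a likely range from 80 nM to 900 nM.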

Compound 4, half-maximal inhibitory concentration: 120 nM
Compound 4: middle estimate off by 2.1-fold (0.32 log units), on the high side; the range from low to high includes it.
By their numbers in this assay, from the lowest: compounds 3 and 4 (each within the scatter of the next); then compound 1. At a limit, above all of these: compound 2.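

Putting 4-methoxybenzyl in place of the (4-((dimethylamino)methyl)phenyl)carbonyl arm gives a 2.0-fold higher number from compound 3 to compound 4 (0.30 log units; within the scatter), so in this assay this position accepts both arms and a carbonyl link is not required there, while methoxy in place of fluoro on an aromatic carbon still gives a 2.1-fold lower number from compound 1 to compound 4 (0.32 log units; beyond the scatter). Cyclopentyl in place of cyclopentylcarbonyl on an amine nitrogen in a ring gives an at least 250-fold lower number from compound 2 to compound 4 (2.39 log units; beyond the scatter), so the loss in compound 2 goes with the cyclopentylcarbonyl group and not with the 4-methoxybenzyl arm it shares with compound 4. Compound 2 stands at a limit and not a number: the limit of > 30000 nM in this assay, at which 1 of the 4 values shown sits.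

From the compounds shown here alone, compounds 3 and 4 change the carbonyl link and the (dimethylamino)methyl group together, so what each contributes alone stays open. Also open, going by these compounds, is how a chloro or a hydroxy group would fare in place of the methoxy.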